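Urea terminus variations on a shared quinoline-amine core

The compounds below may be only part of what the source reports. "The series", "measured", "known", "first", "only" and "open" are said of these compounds alone.

Three analogues sharing one core have been run in a functional assay on NCI-H460 cells (Homo sapiens) for inhibition, read by MTT assay, with a stated time of 72 h; on this read-out higher numbers stand for weaker inhibition and lower numbers for stronger inhibition. Compound 1 `COc1cc(NC(C)CCCNC(=O)Nc2cccc(F)c2)c2ncccc2c1` gives 24000 nM; compound 2 `COc1cc(NC(C)CCCNC(=O)Nc2ccc(Br)cc2)c2ncccc2c1` gives 30000 nM; compound 3 `COc1cc(NC(C)CCCNC(=O)NNC(=O)Nc2ccc(Br)cc2)c2ncccc2c1` gives 27000 nM. Compound 3 stands second highest of the three numbers, with compound 2 nearest and compound 1 furthest, and both of those gaps lie within the scatter. Among the measured compounds shown here, every step so far is flat: a 1.3-fold higher number from compound 1 to compound 2 (0.10 log units; within the scatter), a 1.1-fold higher number from compound 1 to compound 3 (0.05 log units; within the scatter) and a 1.1-fold lower number from compound 2 to compound 3 (0.05 log units; within the scatter), so neither swapping the terminal aryl group nor inserting the carbamoylamino extension moved this assay beyond the scatter.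

Compound 4 `COc1cc(NC(C)CCCNC(=O)Nc2ccc(O)cc2)c2ncccc2c1` differs from compound 3 as follows: 4-hydroxyphenyl in place of ((4-bromophenyl)carbamoyl)amino on an amide-type nitrogen. For the measured compounds named here, the step from compound 2 to compound 3 is the closest precedent, since it removes the same extension in reverse and was within the scatter; the step from compound 1 to compound 2 shows that a change of the ring substituent was also within the scatter. Going by the values given here, no step bearing on this change was beyond the scatter, so compound 4 is expected to show no change at the digits printed from compound 3 to compound 4 (within the scatter), effectively no change. For compound 4 the estimate in this assay is 27000 nM, with a range from 12000 nM to 60000 nM.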

Compound 4, half-maximal inhibitory concentration: 34000 nM
The estimate for compound 4 lay 1.3-fold (0.10 log units) below the measured number; the range from low to high includes it.
By their numbers in this assay, from the lowest: compounds 1, 3, 2 and 4 (each within the scatter of the next).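

In this assay, the group on the amide-type nitrogen now spans fluoro, bromo and hydroxy substitution on the phenyl ring, and the hydroxy compound stays within the scatter of both others (a 1.1-fold higher number from compound 2 to compound 4 (0.05 log units; within the scatter); a 1.4-fold higher number from compound 1 to compound 4 (0.15 log units; within the scatter)). Taking out ((4-bromophenyl)carbamoyl)amino, with 11 heavy atoms, for 4-hydroxyphenyl, with 7, also stays within the scatter (a 1.3-fold higher number from compound 3 to compound 4 (0.10 log units; within the scatter)), so this place has so far accepted all four groups without a step beyond it. No measured evidence available here accounts for these numbers staying together.

Still open, on these data alone, is whether an amine or a carboxylic acid on the phenyl ring in place of hydroxy would give a step beyond the scatter. Equally open, as far as these compounds go, is whether a longer chain on the shared core would do so.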